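Swapping a hydroxyethyl sulfone for a hydroxypiperidine amide

The source may hold more compounds than are shown below. What is called first, only, known or untested is meant among the compounds shown, and "the series" means these compounds.

Measured so far:
compound 1 `CS(=O)(=O)c1ccc(-c2cnc3ccc(-c4cccc(S(=O)(=O)CCO)c4)nn23)cc1`: 8600 nM
compound 2 `CS(=O)(=O)c1ccc(-c2cnc3ccc(-c4ccnc(C(F)(F)F)c4)nn23)cc1`: < 5000 nM (a limit of the assay)

In a physicochemical assay for solubility, at pH 6.5 (a higher number here means a more soluble compound, a lower number a less soluble compound), compound 1 gives 8600 nM. Compound 2 sits at a limit of this assay, < 5000 nM, as noted in the limit of < 5000 nM in this assay, at which 1 of the 2 values shown sits. Going by the values given here, compound 1 is therefore the only one of the two with a numerical reading, and no step between measured compounds that differ in a single place is available to lean on.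

Compound 3 `CS(=O)(=O)c1ccc(-c2cnc3ccc(-c4cccc(C(=O)N5CCC(O)CC5)c4)nn23)cc1` differs from compound 1 by one change: (4-hydroxypiperidin-1-yl)carbonyl in place of (2-hydroxyethyl)sulfonyl on an aromatic carbon. Both groups carry one hydroxyl, and the shared core stays the same. Among the compounds with values here, with no measured step to guide the expectation, the change is expected to move this assay by little, if at all, beyond the usual scatter, perhaps slightly upward.

Compound 3 is expected to give 11000 nM, between 4500 nM and 30000 nM, which implies an expected step of a 1.3-fold higher number from compound 1 to compound 3 (0.11 log units; within the scatter).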

Compound 3, solubility: 178000 nM
Beside the measured number, compound 3's estimate is 16-fold (1.21 log units) below it; measured number outside the range, above it.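

In this assay, the group at this place on the aromatic ring proves able to move the reading far beyond the usual scatter: the exchange gives a 21-fold higher number from compound 1 to compound 3 (1.32 log units; beyond the scatter). Going by these compounds alone, no single-place step was available earlier, so this is the first evidence of how much this position can matter. It also shows that keeping a hydroxyl on the group does not keep the reading unchanged, although nothing at hand explains why this step is so large.

As far as these compounds go, with one exchange at this place, it stays open whether the step follows the carbonyl in place of the sulfonyl, the six-membered non-aromatic ring, or the hydroxyl on that ring. A piperidine amide without the hydroxyl, or an open-chain dimethyl amide, would help to pull these parts apart.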